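The source may hold more compounds than are shown below. What is called first, only, known or untested is meant among the compounds shown, and "the series" means these compounds.

Working notes on the series. Compound 1 `O=C(/C=C/c1ccc(OCCCCO[N+](=O)[O-])c(O)c1)OCCCCO[N+](=O)[O-]` and compound 2 `O=C(/C=C/c1ccc(O)c(O)c1)OCc1c(-c2ccccc2)no[n+]1[O-]` both carry free hydroxy on the aromatic ring; the difference between their two cores is not broken down here. Compound 3 `COc1cc(/C=C/C(=O)OCc2c(-c3ccccc3)no[n+]2[O-])ccc1O` is the methoxy counterpart of compound 2, and compound 4 `COc1cc(/C=C/C(=O)OCCCCO[N+](=O)[O-])ccc1OCCCCO[N+](=O)[O-]` is the methoxy counterpart of compound 1.

In a functional assay on NCI-H157 cells (Homo sapiens) for cytotoxicity, read by resazurin assay, with a stated time of 72 h (on this read-out lower numbers stand for stronger inhibition and higher numbers for weaker inhibition), compound 1 gives only a limit, > 50000 nM. Compound 2 likewise gives only a limit, > 50000 nM. Compound 3 gives 4530 nM. The change methyl in place of hydrogen on an oxygen on an aromatic ring therefore produced an at least 11-fold lower number from compound 2 to compound 3 (1.04 log units; beyond the scatter). The change methyl in place of hydrogen on an oxygen on an aromatic ring is the same change at the same place, though for the pair compound 2 and compound 3 the difference cut one bond further out also reads 3,4-dihydroxyphenyl to 4-hydroxy-3-methoxyphenyl. Since two of the three values sit at the limit of > 50000 nM in this assay, at which 2 of the 3 values shown sit, the starting point for compound 4 is itself only bounded on one side, so the expected step is judged loosely: the expected step is an at least 3.3-fold lower number from compound 1 to compound 4 (0.52 log units; beyond the scatter) because an at least 11-fold lower number from compound 2 to compound 3 (1.04 log units; beyond the scatter) is its measured counterpart. The estimate for compound 4 in this assay is 15000 nM, with 4000 nM to 50000 nM as the expected span.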

Compound 4, half-maximal inhibitory concentration: > 50000 nM
Compound 4: a limit, no number; the forecaster's own chance of this, stated with the estimate: 35%; middle value at least 3.3-fold (0.52 log units) from the limit.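

this assay compound 4 gives > 50000 nM, which is a limit and not a number. Compound 1 also gives only a limit, so no step from compound 1 to compound 4 can be read: the limit of > 50000 nM in this assay, at which 3 of the 4 values shown sit.

The compounds shown leave open whether hydroxy to methoxy changes the number at all on the core of compound 1.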